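The compounds below may be only part of what the source reports. "The series", "measured", "known", "first", "only" and "open" are said of these compounds alone.

Measured compounds:
compound 1, `Cc1ccc(S(=O)(=O)c2cnc3ccc(Cl)cc3c2N2CCC(C)CC2)cc1F`, gives 68% in an assay on isolated protein for displacement of a labelled ligand from metabotropic glutamate receptor 5 (Homo sapiens), with a stated time of 60 min, tested at 1 uM; on this read-out lower numbers stand for less inhibition and higher numbers for more inhibition at the one concentration tested (going by the name of the read-out);
compound 2, `CC1CCN(c2c(S(=O)(=O)c3ccc(F)cc3)cnc3ccc(Cl)cc23)CC1`, gives 89% in this assay.

Compound 2 stands highest of the two numbers, and its nearest neighbour is compound 1, which lies a number 21 percentage points higher from compound 1 to compound 2 (beyond the scatter). Within the data shown here, that single step, a change of the aryl group on the sulfonyl sulfur, is the only measured step available, and it bears on the next change only loosely.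

Compound 3, `CC1CCN(c2c(S(=O)(=O)c3ccccc3)cnc3ccc(Cl)cc23)CC1`, differs from compound 2 as follows: hydrogen in place of fluoro on an aromatic carbon. Among the measured compounds shown here, since the only measured step changed the same aryl group and produced a modest rise, and since here the fluoro is merely removed, the expected movement is small; the estimate is a step of a number 7 percentage points lower from compound 2 to compound 3 (within the scatter), within the scatter. Compound 3 is therefore expected to give about 82% in this assay, with a range from 62% to 95%.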

Compound 3, a percentage reported as inhibition, at one concentration (the size of the read-out at that concentration, not a potency): 59%
For compound 3 the middle estimate is 23 percentage points above the measured one, and the stated range ends above it.
By their numbers in this assay, from the lowest: compounds 3 and 1 (each within the scatter of the next); then compound 2.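

In this assay, the fluoro para to a large group now stands out as a feature that matters on its own: removing it, the change from 4-fluorophenyl to phenyl, gives a number 30 percentage points lower from compound 2 to compound 3 (beyond the scatter). Compound 1 and compound 3 are not separated, with a number 9 percentage points lower from compound 1 to compound 3 (within the scatter), so neither the phenyl group nor the 3-fluoro-4-methylphenyl group reaches the number of compound 2, and the earlier rise with 4-fluorophenyl, a number 21 percentage points higher from compound 1 to compound 2 (beyond the scatter), can now be read against an unsubstituted ring as well. Nothing measured here gives a reason for the effect of this single atom.

The compounds shown leave open whether chloro, methoxy or a nitrile in the place of the fluoro would hold the number of compound 2. They also leave open whether the fluoro would count for as much with a different amine on the shared core.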